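Amide nitrogen alkyl trimming in the hydroxamate series

The source may report more compounds than this note shows. Statements on the series, on what has been measured and on what is new or still open speak of the compounds shown alone.

Measured so far:
compound 1 `CCN(C(=O)c1cc(C(C)C)c(O)cc1O)c1ccc(NC(=O)CCCCCCC(=O)NO)cc1`, 5630 nM
compound 2 `CC(C)c1cc(C(=O)N(c2ccc(NC(=O)CCCCCCC(=O)NO)cc2)C(C)C)c(O)cc1O`, > 10000 nM
compound 3 `CCN(C(=O)c1cc(C(C)C)c(O)cc1O)c1cccc(NC(=O)CCCCCCC(=O)NO)c1`, 1590 nM

In a functional assay on A549 cells (Homo sapiens) for inhibition, read by sulforhodamine B assay, with a stated time of 48 h (a higher number here means a weaker inhibitor of growth, a lower number a stronger inhibitor of growth), compound 1 gives 5630 nM. For compound 2 the value > 10000 nM is a limit of this assay, not a number (the limit of > 10000 nM in this assay, at which 1 of the 3 values shown sits). Compound 3 gives 1590 nM in this assay, the lowest of the two numbers; compound 1 stands higher, beyond the scatter. The difference between the cores of compound 2 and compound 3 is not broken down here.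

The measured step hydrogen in place of methyl on a saturated chain carbon bound to an amide-type nitrogen and a saturated chain carbon gives an at least 1.7-fold lower number from compound 2 to compound 1 (0.24 log units; that floor lies within the scatter). Compound 4 `CC(C)c1cc(C(=O)N(C)c2cccc(NC(=O)CCCCCCC(=O)NO)c2)c(O)cc1O` carries the same kind of change from compound 3, (hydrogen in place of methyl on a saturated chain carbon bound to an amide-type nitrogen), though the place lines differ: in the measured step the carbon is also bound to a saturated chain carbon. Since the measured step starts from a limit, only a modest change is expected; compound 4 is estimated at 1200 nM, a step of a 1.3-fold lower number from compound 3 to compound 4 (0.12 log units; within the scatter), with a likely range from 400 nM to 4000 nM.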

Compound 4, concentration for 50% growth inhibition: 2300 nM
The estimate for compound 4 lay 1.9-fold (0.28 log units) below the measured number, and the stated range covers the measured number.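

In this assay, the change from ethyl to methyl gives a 1.4-fold higher number from compound 3 to compound 4 (0.16 log units; within the scatter), so on the core of compound 3 it produces no step beyond the scatter. Set beside the step on the other core, the result reads: the same change on two cores in this assay, an at least 1.7-fold lower number (0.24 log units; that floor lies within the scatter) from compound 2 to compound 1 and a 1.4-fold higher number (0.16 log units; within the scatter) from compound 3 to compound 4; the limit leaves it open whether they differ. This does not show that the change carries over unaltered from one core to another, nor that it fails to, and the reading on the core of compound 1 rests on a limit for compound 2: the limit of > 10000 nM in this assay, at which 1 of the 4 values shown sits.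

The compounds shown leave open how a hydrogen or a longer chain such as propyl in this place would read on the core of compound 3. They also leave open whether a cyclopropyl group would read differently from ethyl or methyl on either core.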